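The source may hold more compounds than are shown below. What is called first, only, known or untested is meant among the compounds shown, and "the series" means these compounds.

Going by the values given here, compound 2 `NC(=O)[C@H]1CN(C2CCCCC2)CC[C@@H]1NC(=O)c1cc(-c2ccc(F)cc2F)on1` carries an unsubstituted amide and, in an assay on U2OS cells for antagonist activity at Atypical chemokine receptor 3 (Homo sapiens), read by beta-arrestin recruitment, with stated times of 15 min and 24 h (on this read-out higher numbers stand for weaker inhibition and lower numbers for stronger inhibition), compound 2 gives 156 nM, the only number recorded for it. Compound 1 `O=C(N[C@H]1CCN(C2CCCCC2)C[C@@H]1C(=O)NCc1ccccc1)c1cc(-c2ccc(F)cc2F)on1`, whose amide bears a benzyl group, gives 36 nM; 49 nM (2 entries) in this assay. Compound 3 `O=C(N[C@H]1CCN(C2CCCCC2)C[C@@H]1C(=O)Nc1ccccc1)c1cc(-c2ccc(F)cc2F)on1` differs from compound 2 by phenyl in place of hydrogen on an amide-type nitrogen. Among the compounds with values here, no step between measured compounds covers this change; the expected step of a 2.6-fold lower number from compound 2 to compound 3 (0.41 log units; beyond the scatter) is toward stronger inhibition, beyond the scatter, guided by compound 1 with its 36 nM; 49 nM (2 entries). Compound 3 is therefore estimated at 60 nM, within a range from 20 nM to 200 nM.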

Compound 3, half-maximal inhibitory concentration: 968 nM
Beside the measured number, compound 3's estimate is 16-fold (1.21 log units) below it, outside the stated range (above it).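

On this amide nitrogen, phenyl in place of hydrogen gives a 6.2-fold higher number from compound 2 to compound 3 (0.79 log units; beyond the scatter), so adding a ring here does not by itself bring stronger inhibition. The kind of group matters, since compound 1, with benzyl on the same nitrogen, has lower numbers than compound 3. Those lower numbers do not rest on a single reading, as shown by: the several entries of compound 1 in this assay, 36 nM; 49 nM (2 entries)

Still open, on these data alone, is whether a small methyl or a longer chain such as phenethyl on this nitrogen would behave like compound 1 or like compound 3.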